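The source may hold more compounds than are shown below. What is called first, only, known or untested is meant among the compounds shown, and "the series" means these compounds.

Measured so far:
- compound 1, `CSc1nnc(Cc2ccc(Cl)cc2Oc2ccccc2F)[nH]1`: 110%
- compound 2, `CCOc1nnc(Cc2ccc(Cl)cc2Oc2ccccc2Cl)[nH]1`: 120%

In a functional assay on the whole organism (strain NMRI) with Mus musculus as the target, with a stated time of 60 min, at a dose of 5 mg/kg by the intraperitoneal route (a higher number here means a stronger effect of the compound at the dose given, a lower number a weaker effect), compound 2 gives 120%, and compound 1 gives 110%. The gap between these two readings lies within the usual scatter of repeated measurements, so on the numbers shown the two compounds cannot be told apart; compound 2 simply has one of two readings that sit close together.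

Compound 3, `CCOc1nnc(Cc2ccc(Cl)cc2Oc2ccccc2F)[nH]1`, has not yet been measured. It differs from compound 2 in a single place: fluoro in place of chloro on an aromatic carbon. The ring that changes is the same one that already carries fluoro in compound 1, so the fluoro ring is not new to this set, and compound 1 with that ring gives a reading close to compound 2.

For the measured compounds named here, with no measured pair showing this exact change, the expectation rests on the fact that the two measured compounds are indistinguishable. The step from compound 2 to compound 3 is expected to be a number 5 percentage points lower from compound 2 to compound 3 (within the scatter), that is, nothing beyond the scatter. Compound 3 is thus estimated at 115%, with a range from 95% to 135%.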

Compound 3, a percentage reported as activity, at one dose (the size of the read-out at that dose, not a potency): 111%
Compound 3: the middle estimate sits 4 percentage points above what was measured, within the range that was stated.
By their numbers in this assay, from the lowest: compounds 1, 3 and 2 (each within the scatter of the next).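

In this assay, the change from 2-chlorophenoxy to 2-fluorophenoxy, on an aromatic carbon ortho to a large group, now has a direct reading: the exchange of chloro for fluoro gives a number 9 percentage points lower from compound 2 to compound 3 (within the scatter) and so does not separate the two compounds at this dose. A second single change, ethoxy in place of methylsulfanyl on an aromatic carbon with the 2-fluorophenoxy part held the same, gives a number 1 percentage points higher from compound 1 to compound 3 (within the scatter) and likewise leaves the two compounds impossible to tell apart. No separate measurement bears on what lies behind these readings.

All the compounds shown carry a chloro or fluoro group at the ring position, so it remains open whether a different group there, such as methoxy, nitrile or an amine, would give a reading beyond the scatter. The place holding ethoxy or methylsulfanyl is open in the same way, since a longer chain or an amine there is not among these compounds, and a reading at a single dose does not show how the compounds would compare at other doses.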